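Thiadiazole glycoside amides: chain truncation on the free core

The source may report more compounds than this note shows. Statements on the series, on what has been measured and on what is new or still open speak of the compounds shown alone.

Compound 1 `CCCCCCCCCCCC(=O)Nc1nnc(S[C@@H]2O[C@H](COC(C)=O)[C@H](OC(C)=O)[C@H](OC(C)=O)[C@H]2OC(C)=O)s1` and compound 2 `CCCCCCCC/C=C\CCCCCCCCCCCC(=O)Nc1nnc(S[C@@H]2O[C@H](COC(C)=O)[C@H](OC(C)=O)[C@H](OC(C)=O)[C@H]2OC(C)=O)s1` share one core. In an ADME assay on CHO-K1 cells (Cricetulus griseus) for cytotoxicity, read by MTT assay, with a stated time of 24 h (on this read-out higher numbers stand for weaker inhibition and lower numbers for stronger inhibition), compound 1 gives 27700 nM, and compound 2 gives 25200 nM. The change hydrogen in place of dec-1-en-1-yl on a saturated chain carbon, ten or more bonds along the chain from a carbonyl carbon produced a 1.1-fold higher number from compound 2 to compound 1 (0.04 log units; within the scatter). Compound 3 `CCCCCCCC/C=C\CCCCCCCCCCCC(=O)Nc1nnc(S[C@@H]2O[C@H](CO)[C@H](O)[C@H](O)[C@H]2O)s1` carries the other core; the difference between the two cores is not broken down here. In this assay compound 3 is recorded as "not active" (no number reported), with no number reported. Compound 4 `CCCCCCCCCCCC(=O)Nc1nnc(S[C@@H]2O[C@H](CO)[C@H](O)[C@H](O)[C@H]2O)s1` is still to be measured and differs from compound 3 by hydrogen in place of dec-1-en-1-yl on a saturated chain carbon, ten or more bonds along the chain from a carbonyl carbon, the same change as from compound 2 to compound 1. Compound 4 is expected to stand near compound 3 because a 1.1-fold higher number from compound 2 to compound 1 (0.04 log units; within the scatter) is a step within the scatter, so a result without a number is again likely. The estimate for compound 4 in this assay is 80000 nM, expected between 25000 nM and 300000 nM.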

Compound 4, half-maximal inhibitory concentration: "not active" (no number reported)
Compound 4 has no reported number here, so the estimate cannot be set against anything.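

Compound 3 and compound 4 both carry no number in this assay, and no step can be read between them. No supporting data bear on this result. The compounds shown leave open whether dec-1-en-1-yl to hydrogen shifts the read-out on this core.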